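The source may report more compounds than this note shows. Statements on the series, on what has been measured and on what is new or still open speak of the compounds shown alone.

Measured so far in a functional assay on MCF7 cells (Homo sapiens) for inhibition, read by CCK-8 assay, with a stated time of 48 h; a lower number here means a stronger inhibitor, a higher number a weaker inhibitor:

Compound 1 `COc1cc(-c2ccnc3cc(-c4ccc(C(C)(C)C)cc4)nn23)cc(OC)c1OC`: compound 1 gives > 10000 nM, which is a limit of the assay and not a number.
Compound 2 `COc1cc(-c2ccnc3cc(-c4ccc5ccn(C)c5c4)nn23)cc(OC)c1OC`: compound 2 gives 74 nM.
Compound 3 `COc1cc(-c2ccnc3cc(-c4ccc(N(C)C)cc4)nn23)cc(OC)c1OC`: compound 3 gives 44 nM.

Compound 3 has the lowest of the two numbers in this assay; its nearest neighbour is compound 2, and the gap between them, a 1.7-fold lower number from compound 2 to compound 3 (0.23 log units; within the scatter), is within the scatter, so no order between compound 2 and compound 3 can be stated. Within the data shown here, the only large steps are those leaving compound 1: an at least 130-fold lower number from compound 1 to compound 2 (2.13 log units; beyond the scatter) and an at least 220-fold lower number from compound 1 to compound 3 (2.35 log units; beyond the scatter), both of which run from a value that sits at the limit (the limit of > 10000 nM in this assay, at which 1 of the 3 values shown sits).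

Compound 4 `COc1cc(-c2ccnc3cc(-c4ccc5c(ccn5C)c4)nn23)cc(OC)c1OC` differs from compound 3 by 1-methyl-1H-indol-5-yl in place of 4-(dimethylamino)phenyl on an aromatic carbon. The step bearing most directly on it is the one between the two measured aryl groups that are not tert-butyl substituted, a 1.7-fold lower number from compound 2 to compound 3 (0.23 log units; within the scatter), which is within the scatter. Compound 2 already carries a 1-methyl-1H-indol-6-yl group, and compound 4 carries the 1-methyl-1H-indol-5-yl isomer, so the expectation is a number close to both compound 2 and compound 3, with no step beyond the scatter. The expected step is a 1.4-fold higher number from compound 3 to compound 4 (0.13 log units; within the scatter). Compound 4 is therefore estimated at 60 nM in this assay, with a range of 25 nM to 150 nM.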

Compound 4, half-maximal inhibitory concentration: 3 nM
The estimate for compound 4 lay 20-fold (1.30 log units) above the measured number; measured number below the stated range.
By their numbers in this assay, from the lowest: compound 4; then compounds 3 and 2 (each within the scatter of the next). At a limit, above all of these: compound 1.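

Notes on the aryl group at this position, on an aromatic carbon of a five-membered aromatic ring with 2 nitrogen: in this assay, the point of attachment of the methylindole counts, since 1-methyl-1H-indol-5-yl in place of 1-methyl-1H-indol-6-yl gives a 25-fold lower number from compound 2 to compound 4 (1.39 log units; beyond the scatter), a large step between two isomeric groups. Among these compounds, compound 2 and compound 3 could not be put in order, whereas compound 4 stands apart from the 4-(dimethylamino)phenyl group as well, with a 15-fold lower number from compound 3 to compound 4 (1.17 log units; beyond the scatter), the first large step that does not start from a limit. The widest step, an at least 3300-fold lower number from compound 1 to compound 4 (3.52 log units; beyond the scatter), does start from a value that is a limit and not a number: the limit of > 10000 nM in this assay, at which 1 of the 4 values shown sits.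

As far as these compounds go, whether the gain depends on the methyl on the indole nitrogen remains open, as does the outcome with 1H-indol-5-yl, 1-ethyl-1H-indol-5-yl or the isomeric 1-methyl-1H-indol-4-yl. From the compounds shown here alone, all four compounds also keep the rest of the core unchanged, so it is open whether the 1-methyl-1H-indol-5-yl gain would persist with an amine or a hydroxyl in place of a methoxy group.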